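A few compounds are considered here, and "the series" means these few. Any claim that something is new, unique, unknown or untested is made for them only; others in the source may bear on it.

Compound 3 `O=C(Nc1ccc(Oc2ccnc3[nH]ccc23)c(F)c1)c1cc(-c2ccc(F)cc2)ccn1` gives 9520 nM in a functional assay on MCF7 cells (Homo sapiens) for cytotoxicity, read by MTT assay, with a stated time of 72 h; on this read-out higher numbers stand for weaker inhibition and lower numbers for stronger inhibition. Among the three compounds measured it carries the highest number, yet both comparisons stay inside the usual scatter: against compound 1 `Cc1ccc(-c2ccnc(C(=O)Nc3ccc(Oc4ccnc5[nH]ccc45)c(F)c3)c2)cc1` with 8430 nM the step reads a 1.1-fold higher number from compound 1 to compound 3 (0.05 log units; within the scatter), and against compound 2 `CCc1ccc(-c2ccnc(C(=O)Nc3ccc(Oc4ccnc5[nH]ccc45)c(F)c3)c2)cc1` with 7470 nM it reads a 1.3-fold higher number from compound 2 to compound 3 (0.11 log units; within the scatter). So the three compounds cannot be separated on this assay.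

Compound 4 `O=C(Nc1ccc(Oc2ccnc3[nH]ccc23)c(F)c1)c1cc(-c2ccc(F)cc2F)ccn1` has not been measured. It differs from compound 3 by fluoro in place of hydrogen on an aromatic carbon, a fluoro in place of hydrogen on an aromatic carbon, ortho to a large group and meta to a fluoro group; cut one bond further out, the change reads 4-fluorophenyl to 2,4-difluorophenyl.

The two measured steps that touch the same ring, a 1.1-fold higher number from compound 1 to compound 3 (0.05 log units; within the scatter) and a 1.3-fold higher number from compound 2 to compound 3 (0.11 log units; within the scatter), both lie within the scatter, and neither adds a second fluoro. Nothing here points to a change beyond the scatter, so compound 4 is expected to land near compound 3, with a 1.0-fold lower number from compound 3 to compound 4 (0.00 log units; within the scatter) as the estimated step. The estimate for compound 4 is 9500 nM, with a range from 4500 nM to 20000 nM.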

Compound 4, half-maximal inhibitory concentration: > 10000 nM
Compound 4 ended at the assay's limit; the forecaster's own chance of this, stated with the estimate: 10%; middle value at least 1.0-fold (0.02 log units) from the limit.
By their numbers in this assay, from the lowest: compounds 2, 1 and 3 (each within the scatter of the next). At a limit, above all of these: compound 4.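

In this assay compound 4 gives a limit and not a number: the limit of > 10000 nM in this assay, at which 1 of the 4 values shown sits.

The second fluoro, ortho to a large group, can therefore be read only as a floor, an at least 1.0-fold higher number from compound 3 to compound 4 (0.02 log units; that floor lies within the scatter), and the comparisons with the two alkyl-bearing compounds are floors as well, an at least 1.3-fold higher number from compound 2 to compound 4 (0.12 log units; that floor lies within the scatter) and an at least 1.1-fold higher number from compound 1 to compound 4 (0.07 log units; that floor lies within the scatter). Going by these compounds alone, compounds 1, 2 and 3 left this place on the ring unsubstituted, so compound 4 gives the first look at it, and adding a fluoro here brings no lower number, though the true size of the step remains unknown.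

On these data alone, whether an amine or a methoxy group at this place would bring the number clearly down remains open. So does the question of whether a fluoro here would behave the same way with a methyl or ethyl group on the ring instead of the existing fluoro.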